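This account rests on a few compounds, and the source may have more. Where it says the series, first, only, none or still open, it means among the compounds named here.

Measured so far:
compound 1, `NS(=O)(=O)c1ccc(N2N=C(c3ccc(Oc4ccccc4)cc3)CC2c2ccccc2Cl)cc1`: 29000 nM
compound 2, `NS(=O)(=O)c1ccc(N2N=C(c3ccc(Oc4ccccc4)cc3)CC2c2ccc(F)cc2)cc1`: 25000 nM

Both were tested in an ADME assay on Vero 76 cells (Chlorocebus sabaeus) for cytotoxicity, read by MTT assay, with a stated time of 96 h; on this read-out lower numbers stand for higher toxicity in this test and higher numbers for lower toxicity in this test. For the measured compounds named here, compound 2 holds the lower of the two numbers, but the only step so far, a 1.2-fold lower number from compound 1 to compound 2 (0.06 log units; within the scatter), lies within the scatter, so the two compounds cannot really be told apart on this read-out.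

The next compound is compound 3, `Cc1ccccc1C1CC(c2ccc(Oc3ccccc3)cc2)=NN1c1ccc(S(N)(=O)=O)cc1`, which differs from compound 2 in one place: 2-methylphenyl in place of 4-fluorophenyl on a saturated ring carbon. Going by the values given here, the only measured step that touches this position is the one from compound 1 to compound 2, which swapped one aryl group for another at the same saturated ring carbon and gave a 1.2-fold lower number from compound 1 to compound 2 (0.06 log units; within the scatter), a change too small to count. That single step is the whole basis for any expectation here, and it points to no movement beyond the scatter. Compound 3 is therefore expected to behave much like compound 2, with an expected step of a 1.1-fold higher number from compound 2 to compound 3 (0.03 log units; within the scatter). The estimate for compound 3 in this assay is 27000 nM, with a range from 12000 nM to 60000 nM.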

Compound 3, half-maximal cytotoxic concentration: 90000 nM
The estimate for compound 3 lay 3.3-fold (0.52 log units) below the measured number; the measured number lies above the stated range.
By their numbers in this assay, from the lowest: compounds 2 and 1 (each within the scatter of the next); then compound 3.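

Until now the aryl group on this saturated ring carbon could change without a readable effect, but in this assay the change to 2-methylphenyl brings a step beyond the scatter, a 3.6-fold higher number from compound 2 to compound 3 (0.56 log units; beyond the scatter), towards lower toxicity in this test. The same direction appears in a 3.1-fold higher number from compound 1 to compound 3 (0.49 log units; beyond the scatter), where methyl takes the place of chloro on an aromatic carbon, so the 2-chlorophenyl of compound 1 and the 4-fluorophenyl of compound 2 stay together while the 2-methylphenyl of compound 3 stands apart from both. Both steps are modest, and nothing measured here accounts for them.

These three compounds leave open whether the shift belongs to the methyl group alone or would also come with other groups on this phenyl ring, such as an ethyl or a methoxy in the same place, or with a 4-methylphenyl at this saturated ring carbon. Also open, from the compounds shown here alone, is whether the same step would appear if the phenoxy group of the shared core gave way to a simple amine.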